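From compound 1 to compound 4: shrinking one side chain

The source may report more compounds than this note shows. Statements on the series, on what has been measured and on what is new or still open speak of the compounds shown alone.

Among the measured compounds shown here, in a functional assay for inhibition, with Rattus norvegicus as the target (on this read-out higher numbers stand for weaker inhibition and lower numbers for stronger inhibition), compound 1 (`CC(/N=c1\c(O)c(O)\c1=N/c1ccc(C#N)cc1)C(C)(C)C`) gives 520 nM, the lower of the only two exact numbers available. Compound 2 (`CC(=O)c1ccc(/N=c2\c(O)c(O)\c2=N/C(C)C(C)(C)C)cc1`) gives 21200 nM, with acetyl in place of cyano on an aromatic carbon. Compound 3 (`CC(/N=c1\c(O)c(O)\c1=N/c1ccc(C(F)(F)F)cc1)C(C)(C)C`) reads > 30000 nM, which is a limit of the assay and not a number.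

Compound 4 (`C/N=c1\c(O)c(O)\c1=N/c1ccc(C#N)cc1`) keeps the cyano group but has methyl in place of 1,2,2-trimethylpropyl on a double-bonded nitrogen. For the measured compounds named here, no measured step touches that nitrogen substituent, so the evidence is only indirect. It shows how far single changes elsewhere can move compound 1: the measured steps are a 41-fold higher number from compound 1 to compound 2 (1.61 log units; beyond the scatter) and an at least 57-fold higher number from compound 1 to compound 3 (1.76 log units; beyond the scatter), both large. On that slender basis, a large rise in this assay is expected, though its size is quite uncertain. The expected change is a 15-fold higher number from compound 1 to compound 4 (1.19 log units; beyond the scatter). The estimated value for compound 4 is 8000 nM, with an expected range of 1200 nM to 30000 nM.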

Compound 4, half-maximal inhibitory concentration: > 30000 nM
Compound 4: a limit, no number; the forecaster's own chance of this, stated with the estimate: 25%; middle value at least 3.7-fold (0.57 log units) from the limit.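

This is the first change shown at the double-bonded nitrogen, and it shows that the cyano group alone does not secure the low number of compound 1. With the cyano group kept, methyl in place of 1,2,2-trimethylpropyl in this assay gives an at least 57-fold higher number from compound 1 to compound 4 (1.76 log units; beyond the scatter), so this side chain counts as well as the group on the aromatic carbon. The reading for compound 4 is a limit of the assay and not a number, so the step is only a floor and its full size cannot be read: the limit of > 30000 nM in this assay, at which 2 of the 4 values shown sit.

The compounds shown leave open how the number changes between these two extremes, for instance with an ethyl or isopropyl chain or a cyclohexyl ring on that nitrogen. They also leave open what a side chain carrying an amine or a carboxylic acid would do there.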